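The source may hold more compounds than are shown below. What is called first, only, known or untested is meant among the compounds shown, and "the series" means these compounds.

In a functional assay (aorta) with Oryctolagus cuniculus as the target (on this read-out lower numbers stand for tighter binding and higher numbers for weaker binding), compound 1 `CCCCc1nc2cccnc2n1Cc1cc(Cl)c(O)c(Cl)c1` gives 63.1 nM and compound 2 `CCCCc1nc2c(C)ccnc2n1Cc1cc(Cl)c(O)c(Cl)c1` gives 10 nM, so compound 2 holds the lower of the two numbers. Within the data shown here, the single measured step, a 6.3-fold lower number from compound 1 to compound 2 (0.80 log units; beyond the scatter), comes from methyl in place of hydrogen on an aromatic carbon. Compound 3 `Cc1ccnc2c1nc(C1CC1)n2Cc1cc(Cl)c(O)c(Cl)c1` differs from compound 2 in one group: cyclopropyl in place of butyl on an aromatic carbon. Here cyclopropyl stands in place of butyl on an aromatic carbon, between two ring nitrogen atoms. Among the measured compounds shown here, no measured pair changes this group, so there is no direct evidence for the size or direction of the step. For the measured compounds named here, the step of a 6.3-fold lower number from compound 1 to compound 2 (0.80 log units; beyond the scatter) lies at a different place and shows only that a single small change can move this assay beyond the scatter. A modest move towards a higher number, smaller than that step, is therefore a cautious expectation, and little change remains possible. The expected change is a 2.5-fold higher number from compound 2 to compound 3 (0.40 log units; beyond the scatter). For compound 3 the estimated value is 25 nM, with an estimated range from 5 nM to 120 nM.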

Compound 3, dissociation constant: 2 nM
The estimate for compound 3 lay 13-fold (1.10 log units) above the measured number; measured number below the stated range.
By their numbers in this assay, from the lowest: compound 3; then compound 2; then compound 1.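

At this position, on an aromatic carbon between two ring nitrogen atoms, there is now a measured step: in this assay, cyclopropyl in place of butyl gives a 5.0-fold lower number from compound 2 to compound 3 (0.70 log units; beyond the scatter). The butyl chain is therefore not needed at its full length to reach a low number here, since the smaller group with one three-membered ring gives a lower number than the open chain does. Nothing measured here explains why the number falls, so the step stands as an observation without a known cause.

With only butyl and cyclopropyl shown at this position, it remains open whether the gain comes from the ring itself or from the smaller number of carbon atoms; a propyl chain would help separate the two, while cyclobutyl would show whether a larger ring is also accepted. From the compounds shown here alone, it is also open whether cyclopropyl would give a similar step in the core of compound 1, which lacks the methyl group carried by compound 2 and compound 3.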